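Chloro for hydrogen, carried from one core to another

The compounds below may be only part of what the source reports. "The series", "measured", "known", "first", "only" and "open" are said of these compounds alone.

Compound 1 `CCC(=O)Oc1c(OC)c(OC)c(OC(=O)CC)c2ccccc12` and compound 3 `CCC(=O)Oc1c(OC)c(OC)c(OC(=O)CC)c2cc(Cl)ccc12` share a core. In a physicochemical assay for lipophilicity (a lower number here means a more polar compound, a higher number a more lipophilic compound), compound 1 gives 3.44 and compound 3 gives 4.3. The change between them is chloro in place of hydrogen on an aromatic carbon and produced a number 0.86 log units higher from compound 1 to compound 3 (beyond the scatter). Compound 2 `COc1c(OC)c(OC(=O)C(C)(C)C)c2ccccc2c1OC(=O)C(C)(C)C` stands on a different core; the difference between the two cores is not broken down here. In this assay compound 2 gives 5.69, the highest of the three measured values. Compound 4 `COc1c(OC)c(OC(=O)C(C)(C)C)c2cc(Cl)ccc2c1OC(=O)C(C)(C)C` has not yet been measured; it differs from compound 2 by chloro in place of hydrogen on an aromatic carbon, the same change as between compound 1 and compound 3, at a place described in the same words. The expected step is a number 0.81 log units higher from compound 2 to compound 4 (beyond the scatter), resting on a number 0.86 log units higher from compound 1 to compound 3 (beyond the scatter). Compound 4 is therefore estimated at 6.5 in this assay, with 6.1 to 6.9 as the likely range.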

Compound 4, partition coefficient: 6.6
For compound 4 the middle estimate is 0.10 log units below the measured one, and the stated range covers the measured number.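

In this assay, the chloro-for-hydrogen change gives a number 0.91 log units higher from compound 2 to compound 4 (beyond the scatter), in the same direction as a number 0.86 log units higher from compound 1 to compound 3 (beyond the scatter), and both steps are modest and beyond the scatter. For the compounds shown here, the change therefore carries across these two cores with a similar size, but two pairs show only that these two cores agree and establish no rule for the series. No measurement shown accounts for the size of either step or for the difference between the cores.

On these data alone, it remains open whether fluoro, bromo or an amine in place of the chloro would give a step of similar size. As far as these compounds go, whether the chloro step would hold on a core carrying longer ester chains also remains open.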